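A few compounds are considered here, and "the series" means these few. Any claim that something is new, unique, unknown or untested is made for them only; others in the source may bear on it.

Measured compounds:
Compound 1, `N#Cc1ccccc1CN1CCc2c(sc(NC(=O)c3ccccc3Cl)c2C(N)=O)C1`, gives 10400 nM in a functional assay on HL-60 cells (Homo sapiens) for antiproliferative activity, with a stated time of 24 h; a lower number here means a stronger inhibitor, a higher number a weaker inhibitor.
Compound 2, `NC(=O)c1c(NC(=O)c2ccccc2Cl)sc2c1CCN(C(=S)Nc1ccccc1)C2`, gives 5940 nM in this assay.

Among the measured compounds shown here, the single step between them, a 1.8-fold lower number from compound 1 to compound 2 (0.24 log units; within the scatter), exchanges the group on the amine nitrogen in the ring and leaves the two values within the scatter; compound 2 holds the lower of the two numbers, but compound 1 sits within the scatter of it, so neither can be called the stronger.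

Compound 3, `NC(=O)c1c(NC(=O)c2ccccc2Cl)sc2c1CCN(C(=S)Nc1ccccc1I)C2`, is not yet measured. It differs from compound 2 by iodo in place of hydrogen on an aromatic carbon. For the measured compounds named here, no measured step touches this change: the one step known alters a different part of the molecule and gives no guide to the size or direction of an effect here. The expectation for compound 3 therefore rests on compound 2 alone, with a wide range. Compound 3 is estimated at 5000 nM, between 1500 nM and 18000 nM. The expected step, a 1.2-fold lower number from compound 2 to compound 3 (0.07 log units; within the scatter), is none beyond the scatter.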

Compound 3, half-maximal inhibitory concentration: 4430 nM
Estimate against measurement, compound 3: 1.1-fold (0.05 log units) above; the range from low to high includes it.
By their numbers in this assay, from the lowest: compounds 3, 2 and 1 (each within the scatter of the next, the first and the last beyond it).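

Iodo in place of hydrogen is the first change shown on the phenyl ring of the anilino group. In this assay it gives a 1.3-fold lower number from compound 2 to compound 3 (0.13 log units; within the scatter) and so leaves phenyl and 2-iodophenyl at this carbon indistinguishable. Among the compounds shown here, the wider exchange on the amine nitrogen in the ring gives a 2.3-fold lower number from compound 1 to compound 3 (0.37 log units; beyond the scatter) and is the only step here beyond the scatter, though modest, while compound 2 stays within the scatter of both other compounds. No measurement at hand accounts for these numbers.

Going by these compounds, whether fluoro, chloro, an amine or a carboxylic acid on this same carbon would shift the number beyond the scatter remains open. So does whether iodo on another carbon of that ring would behave as it does here.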